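Chloro to fluoro on the aryl of compound 2

The source may report more compounds than this note shows. Statements on the series, on what has been measured and on what is new or still open speak of the compounds shown alone.

Going by the values given here, compound 1 `CC(C)N1CCN(Cc2csc(N)c2C(=O)c2ccc(Cl)cc2)CC1` gives 7.3% in a functional assay on CHO cells with adenosine receptor A1 (Homo sapiens) as the target, read by cAMP accumulation and immunoassay, with a stated time of 6 min, tested at 1 uM (a lower number here means a stronger effect, a higher number a weaker effect of the compound at the concentration tested), and compound 2 `Nc1scc(CN2CCN(c3ccc(F)cc3Cl)CC2)c1C(=O)c1ccc(Cl)cc1` gives -39%, the lowest of the two numbers known here. Among the compounds with values here, the one measured step, a number 46.3 percentage points lower from compound 1 to compound 2 (beyond the scatter), came with 2-chloro-4-fluorophenyl in place of isopropyl on an amine nitrogen in a ring. Compound 3 `Nc1scc(CN2CCN(c3ccc(F)cc3F)CC2)c1C(=O)c1ccc(Cl)cc1` differs from compound 2 by fluoro in place of chloro on an aromatic carbon. Within the data shown here, no measured step concerns such a swap, so no shift beyond the scatter is expected; the estimated step is a number 9 percentage points higher from compound 2 to compound 3 (within the scatter). Compound 3 is therefore expected to give about -30%, within -60% to 0%.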

Compound 3, a percentage reported as activity, at one concentration (the size of the read-out at that concentration, not a potency): -66%
Compound 3: the middle estimate sits 36 percentage points above what was measured, outside the stated range (below it).
By their numbers in this assay, from the lowest: compound 3; then compound 2; then compound 1.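

In this assay, this aromatic carbon, ortho to a large group, proves sensitive to the halogen it carries: fluoro in place of chloro gives a number 27 percentage points lower from compound 2 to compound 3 (beyond the scatter), although one heavy atom simply replaces another. The aryl series also extends the gain over the isopropyl compound, with 2,4-difluorophenyl giving a number 73.3 percentage points lower from compound 1 to compound 3 (beyond the scatter). Nothing available here accounts for the halogen effect. Open, on these data alone, is how hydrogen, a methyl or a methoxy group would read on this carbon, and whether the trend continues beyond these two halogens.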